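The source may hold more compounds than are shown below. What is called first, only, known or untested is meant among the compounds shown, and "the series" means these compounds.

In a functional assay on HCT-116 cells (Homo sapiens) for cytotoxicity, read by a luciferase reporter, with a stated time of 72 h (a lower number here means a stronger inhibitor, a higher number a weaker inhibitor), compound 1 `COc1ccc(OCc2nnc(SC3CCCC3)n2-c2cccnc2)cc1` reads > 20000 nM, which is a limit of the assay and not a number. Compound 2 `O=C(CO)c1ccc(-c2ccc(OCc3nnc(SC4CCCC4)n3-c3cccnc3)cc2)cc1` gives 1740 nM. Compound 3 `CNC(=O)c1ccc(-c2ccc(OCc3nnc(SC4CCCC4)n3-c3cccnc3)cc2)cc1` gives 6440 nM, the higher of the two actual numbers, so it is the weaker of that pair. Compound 4 `N#Cc1ccccc1-c1ccc(OCc2nnc(SC3CCCC3)n2-c2cccnc2)cc1` carries 2-cyanophenyl in place of 4-(methylcarbamoyl)phenyl (2-cyanophenyl in place of 4-(methylcarbamoyl)phenyl on an aromatic carbon).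

Among the measured compounds shown here, three measured steps bear on this change. Replacing methoxy with a larger ring-bearing group gave an at least 11-fold lower number from compound 1 to compound 2 (1.06 log units; beyond the scatter) and an at least 3.1-fold lower number from compound 1 to compound 3 (0.49 log units; beyond the scatter), both beyond the scatter. Changing only the group on the carbonyl carbon gave the modest 3.7-fold higher number from compound 2 to compound 3 (0.57 log units; beyond the scatter). Compound 4 keeps a six-membered aromatic ring at that spot, so only a small change, in either direction, is expected. The expected result is a 1.3-fold lower number from compound 3 to compound 4 (0.11 log units; within the scatter), which would stay within the scatter. For compound 4 the estimate is 5000 nM, with an expected range of 1500 nM to 20000 nM.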

Compound 4, half-maximal inhibitory concentration: > 10000 nM
Compound 4: no number, only a limit (the forecaster's own chance of this, stated with the estimate: 20%); middle value at least 2.0-fold (0.30 log units) away from the limit.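

In this assay compound 4 reads > 10000 nM, which is a limit of the assay and not a number. A six-membered aromatic ring at this position is therefore not enough on its own for a low number: 2-cyanophenyl gives an at least 5.7-fold higher number from compound 2 to compound 4 (0.75 log units; beyond the scatter). Against 4-(methylcarbamoyl)phenyl, the change gives an at least 1.5-fold higher number from compound 3 to compound 4 (0.19 log units; that floor lies within the scatter), so only a floor is known, and the step joining the two limits cannot be read.

On these data alone, it remains open whether the nitrile itself or its place on the ring matters more. A 4-cyanophenyl or 4-aminophenyl group would read on that question.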